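A few compounds are considered here, and "the series" means these few. Any claim that something is new, unique, unknown or untested is made for them only; others in the source may bear on it.

Series notes on the solubility read-out. In a physicochemical assay for solubility, read by nephelometry, measured as kinetic solubility, at pH 2.0 (on this read-out lower numbers stand for lower solubility and higher numbers for higher solubility), compound 1 `NCc1csc(NC(=O)c2cnnn2Cc2ccccc2)n1` returns only a limit, > 100 ug/mL, and not a number. Compound 3 `NCc1csc(NC(=O)c2ccon2)n1` gives 50 ug/mL in this assay. Compound 2 `CC(C)(C)c1cc(C(=O)Nc2ccncc2)n(Cc2ccccc2)n1` likewise returns only a limit in this assay, > 100 ug/mL. Among the measured compounds shown here, on the values shown, compound 2 therefore stands at the limit of > 100 ug/mL in this assay, at which 2 of the 3 values shown sit, sharing that position with compound 1, while compound 3 is the one compound of the three with a plain number rather than a limit.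

Compound 4 `CC(C)(C)c1cc(C(=O)Nc2cccnc2)n(Cc2ccccc2)n1` differs from compound 2 in one place: pyridin-3-yl in place of pyridin-4-yl on an amide-type nitrogen. No step of this kind is measured among the compounds shown, so the size of the move from compound 2 to compound 4 in this assay cannot be read off from any pair; it can only be expected. Compound 2 sits at the limit of > 100 ug/mL in this assay, at which 2 of the 3 values shown sit, and so does compound 1. The step of a number no higher from compound 2 to compound 4 (the limit leaves the size open) is therefore expected to be none beyond the usual scatter, with the most likely outcome being that compound 4 also returns only a limit. Compound 4 is accordingly estimated at 100 ug/mL in this assay, with a range from 50 ug/mL to 100 ug/mL.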

Compound 4, solubility: > 100 ug/mL
Compound 4 gave a limit, no number (the forecaster's own chance of this, stated with the estimate: 80%); the middle value sits exactly at the limit.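

Compound 2 and compound 4 both return only a limit in this assay, so no step between them can be read: the limit of > 100 ug/mL in this assay, at which 3 of the 4 values shown sit.

The compounds shown leave open whether pyridin-3-yl in place of pyridin-4-yl on an amide-type nitrogen makes any difference in this assay.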